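This account rests on a few compounds, and the source may have more. Where it says the series, first, only, none or still open, it means among the compounds named here.

Notes on the series. Compound 1 `Cn1c(SCc2ccc(Cl)cc2)nnc1-c1cc([N+](=O)[O-])cc([N+](=O)[O-])c1` carries a (4-chlorobenzyl)sulfanyl group; in an ADME assay on A-431 cells (Homo sapiens) for cytotoxicity, with a stated time of 48 h (on this read-out lower numbers stand for stronger inhibition and higher numbers for weaker inhibition), compound 1 gives only the limit > 30000 nM. Compound 2 `CCCSc1nnc(-c2cc([N+](=O)[O-])cc([N+](=O)[O-])c2)n1Cc1ccccc1` gives the limit > 30000 nM in this assay. Compound 3 `CCCCCCCCSc1nnc(-c2cc([N+](=O)[O-])cc([N+](=O)[O-])c2)n1Cc1ccccc1` likewise gives the limit > 30000 nM in this assay, so the step that the two limits leave unreadable from compound 2 to compound 3 cannot be read. Going by the values given here, compound 3 thus stands at the limit of this assay, where every value so far sits (the limit of > 30000 nM in this assay, at which 3 of the 3 values shown sit). Compound 4 `O=[N+]([O-])c1cc(-c2nnc(SCc3ccc(Cl)cc3)n2Cc2ccccc2)cc([N+](=O)[O-])c1` differs from compound 3 by 4-chlorophenyl in place of heptyl on a saturated chain carbon bound to a sulfur. Among the compounds with values here, no measured step bears on this change; compound 1, which shares the (4-chlorobenzyl)sulfanyl group, also sits at the limit > 30000 nM. Compound 4 is therefore expected to remain at the limit, the step that the limit leaves unreadable from compound 3 to compound 4 expected to stay unreadable. The estimate for compound 4 is 40000 nM, from 20000 nM to 100000 nM.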

Compound 4, half-maximal inhibitory concentration: > 30000 nM
Compound 4 was reported as a limit; the forecaster's own chance of this, stated with the estimate: 85%; the middle value does not contradict the limit.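

Compound 4 adds no readable step to compound 1, compound 2 and compound 3 in this assay, all being limits: the limit of > 30000 nM in this assay, at which 4 of the 4 values shown sit.

The compounds shown leave open how any of these changes in the groups would affect cytotoxicity, as none gives a numerical value.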